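The source may report more compounds than this note shows. Statements on the series, on what has been measured and on what is new or still open speak of the compounds shown alone.

Measured so far:
compound 1, `O/N=C(\CCN1CCN(c2ccccn2)CC1)c1ccccc1`: 70%
compound 2, `O/N=C(\CCN1CCN(c2ccccn2)CC1)c1ccc(F)cc1`: 74%

In a functional assay on HEK293 cells with D(4) dopamine receptor (Homo sapiens) as the target, read by FLIPR (a lower number here means a smaller maximal response, a higher number a larger maximal response), compound 1 gives 70%, the lowest of the two numbers, with compound 2 nearest at 74%; the step of a number 4 percentage points higher from compound 1 to compound 2 (within the scatter) lies within the scatter. Compound 3, `N#Cc1cccnc1N1CCN(CC/C(=N\O)c2ccccc2)CC1`, differs from compound 1 by cyano in place of hydrogen on an aromatic carbon. Going by the values given here, the only comparable step, fluoro in place of hydrogen on an aromatic carbon from compound 1 to compound 2, stayed within the scatter, so no step beyond the scatter is expected here: a number 2 percentage points higher from compound 1 to compound 3 (within the scatter). Compound 3 is therefore estimated at 72%, between 55% and 88%.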

Compound 3, largest response reached (reported as efficacy), in percent of the reference or control that the assay uses: 64%
Compound 3: middle estimate off by 8 percentage points, on the high side; the measured number falls inside the stated range.
By their numbers in this assay, from the lowest: compounds 3, 1 and 2 (each within the scatter of the next).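

In this assay, the change from pyridin-2-yl to 3-cyanopyridin-2-yl gives a number 6 percentage points lower from compound 1 to compound 3 (within the scatter), so this ring carbon, ortho to a large group and two atoms from the ring nitrogen, carries cyano without a shift in maximal response beyond the scatter. Going by these compounds alone, the earlier fluoro step lay on the other aromatic ring, so this is the first reading on the ring with the nitrogen. Nothing available explains this result. On these data alone, whether an amine, a carboxylic acid or a methoxy group on this carbon would move the response beyond the scatter stays open. So does the outcome of cyano on the other carbons of this ring.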